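A ring hydroxy added to the fluoromethyl compound

The source may hold more compounds than are shown below. What is called first, only, known or untested is meant among the compounds shown, and "the series" means these compounds.

Values in a functional assay on P388 cells (Mus musculus) for antiproliferative activity, with a stated time of 72 h; on this read-out higher numbers stand for an effect only at larger amounts of compound and lower numbers for an effect already at smaller amounts:
compound 1 `Cc1cn([C@H]2C[C@H](CF)[C@@H](CO)O2)c(=O)[nH]c1=O`: > 100 uM
compound 2 `Cc1cn([C@H]2C[C@H](CN)[C@@H](CO)O2)c(=O)[nH]c1=O`: > 100 uM
compound 3 `Cc1cn([C@H]2C[C@H](CO)[C@@H](CO)O2)c(=O)[nH]c1=O`: 5 uM

Compound 1 sits at > 100 uM, which is a limit and not a number. This is the limit of > 100 uM in this assay, at which 2 of the 3 values shown sit. Compound 2 gives > 100 uM, also a limit. Only compound 3 gives a number, 5 uM.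

Compound 4 `Cc1cn([C@@H]2O[C@H](CO)[C@@H](CF)[C@@H]2O)c(=O)[nH]c1=O` keeps the fluoromethyl group of compound 1 and gains hydroxy in place of hydrogen on a saturated ring carbon.

The measured steps all concern the saturated chain carbon. Hydroxy in place of fluoro gave an at least 20-fold lower number from compound 1 to compound 3 (1.30 log units; beyond the scatter), and hydroxy in place of amino gave an at least 20-fold lower number from compound 2 to compound 3 (1.30 log units; beyond the scatter), both large. Amino in place of fluoro gave a step that the two limits leave unreadable from compound 1 to compound 2. Among the compounds with values here, compound 4 keeps the fluoro that compound 3 lacks, and no measured compound carries a hydroxy on a ring carbon, so these steps do not carry over to the new change.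

Compound 4 is therefore expected to stay with compound 1 at > 100 uM, a limit, with no step beyond the scatter in either direction in this assay. The step expected is a step that the limit leaves unreadable from compound 1 to compound 4. For compound 4 the estimate is 150 uM, with an expected range from 50 uM to 400 uM.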

Compound 4, concentration for half-maximal effect: > 100 uM
Compound 4 ended at the assay's limit; the forecaster's own chance of this, stated with the estimate: 80%; the middle value lies beyond the limit too.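

In this assay compound 4 gives > 100 uM, which is a limit. Compound 1 also stands at a limit, so no step can be read between these two compounds: the limit of > 100 uM in this assay, at which 3 of the 4 values shown sit.

The compounds shown leave open whether hydroxy in place of hydrogen on a saturated ring carbon changes the value of the fluoromethyl compound in either direction.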